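This account rests on a few compounds, and the source may have more. Where it says the series, first, only, none or still open, it means among the compounds named here.

For the measured compounds named here, in a functional assay on RAW264.7 cells (Mus musculus) for inhibition, read by Griess assay, with a stated time of 24 h (a lower number here means that less compound is needed, a higher number that more compound is needed for the effect), compound 1 `OCc1ccc(C2=NCCc3cc(O)c(O)cc32)o1` gives 203000 nM, while compound 2 `Oc1cc2c(cc1O)C(c1ccco1)=NCC2` gives 18100 nM, the lower of the two numbers so far. Compound 3 `CC1=NCCc2cc(O)c(O)cc21` changes the core's other substituent: methyl in place of furan-2-yl on a carbon with a double bond to nitrogen. Going by the values given here, only one measured step bears on this, and only indirectly. The large 11-fold lower number from compound 1 to compound 2 (1.05 log units; beyond the scatter) shows that a single change on the furan-2-yl group of compound 1 can move the number well beyond the scatter. Among the compounds with values here, no measured compound lacks furan-2-yl, so neither the size nor the direction of the next step is secure. A moderate move towards a higher number is expected, with the outcome possibly staying within the scatter. The estimated change is a 2.8-fold higher number from compound 2 to compound 3 (0.44 log units; beyond the scatter). For compound 3 the expected value is 50000 nM, within an estimated range of 12000 nM to 200000 nM.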

Compound 3, half-maximal effective concentration: 209000 nM
Compound 3: middle estimate off by 4.2-fold (0.62 log units), on the low side; measured number above the stated range.
By their numbers in this assay, from the lowest: compound 2; then compounds 1 and 3 (each within the scatter of the next).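

In this assay, methyl in place of furan-2-yl on a carbon with a double bond to nitrogen brings a 12-fold higher number from compound 2 to compound 3 (1.06 log units; beyond the scatter) and so gives the first measured size and direction for a change at this position. Compound 1 gives 203000 nM and compound 3 gives 209000 nM and these two lie within the scatter of each other, which leaves compound 2 alone at the low end of the three numbers. No measurement shown explains the size of this step.

From the compounds shown here alone, it remains open whether a second aromatic ring such as phenyl would keep a number close to that of compound 2, or whether a longer chain such as propyl would fall nearer to compound 3. Going by these compounds, the effect of an amine or a carboxylic acid at this position also remains unknown.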